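The compounds below may be only part of what the source reports. "The series", "measured", "known", "first", "only" and "open" are said of these compounds alone.

Two compounds of the series have numbers in a functional assay on SK-OV-3 cells (Homo sapiens) for cytotoxicity; a lower number here means a stronger inhibitor, a higher number a weaker inhibitor: compound 1 `O=C(CCCCCCc1nc2ccc(F)cc2[nH]1)NO` gives 1900 nM, and compound 2 `O=C(CCCCCCc1nc2ccc(-c3ccccc3)cc2[nH]1)NO` gives 100 nM, the lowest of the two. Going by the values given here, the single measured step, a 19-fold lower number from compound 1 to compound 2 (1.28 log units; beyond the scatter), concerns phenyl in place of fluoro on an aromatic carbon. Compound 3 `O=C(CCCCCCc1nc2ccc(-c3ccc(F)cc3)cc2[nH]1)NO` differs from compound 2 by fluoro in place of hydrogen on an aromatic carbon. Among the compounds with values here, no measured step covers this change, and the only step concerns a different change, so it gives no direction. Compound 3 is therefore expected to show a 1.1-fold lower number from compound 2 to compound 3 (0.05 log units; within the scatter), within the scatter. The estimate for compound 3 in this assay is 90 nM, range 40 nM to 220 nM.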

Compound 3, half-maximal inhibitory concentration: 1200 nM
For compound 3 the middle estimate is 13-fold (1.12 log units) below the measured one; the whole stated range lies below it.
By their numbers in this assay, from the lowest: compound 2; then compounds 3 and 1 (each within the scatter of the next).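

On the six-membered aromatic ring of carbon only, a single fluoro para to a large group is not a neutral change: phenyl to 4-fluorophenyl in this assay gives a 12-fold higher number from compound 2 to compound 3 (1.08 log units; beyond the scatter). The advantage of phenyl over fluoro on the core does not carry over to 4-fluorophenyl, as a 1.6-fold lower number from compound 1 to compound 3 (0.20 log units; within the scatter) shows. No evidence at hand bears on this result.

Open, as far as these compounds go, is whether this step is peculiar to fluoro or also follows with chloro, methyl or methoxy at the same place. Also open, from the compounds shown here alone, is whether it persists with a longer chain ending in the hydroxamic acid.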